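A few compounds are considered here, and "the series" means these few. Any claim that something is new, unique, unknown or untested is made for them only; others in the source may bear on it.

In an ADME assay on MDBK cells (Bos taurus) for cytotoxicity, read by MTT assay, with a stated time of 96 h (a higher number here means that more compound is tolerated, a lower number that less compound is tolerated), the measured compounds stand as follows. Compound 1 `COc1ccc(-c2nc3cc(Cl)c(Cl)cc3[nH]2)cc1` gives 2500 nM. Compound 2 `CN1CCN(CC(=O)Nc2ccc(-c3nc4cc(Cl)c(Cl)cc4[nH]3)cc2)CC1` gives 90000 nM. Compound 3 `Cn1c(-c2ccc([N+](=O)[O-])cc2)nc2cc(C(F)(F)F)ccc21` gives > 100000 nM, which is a limit of the assay and not a number.

Compound 3 thus stands at the limit of > 100000 nM in this assay, at which 1 of the 3 values shown sits, so its true value is not pinned down. Compound 4 `Cn1c(-c2ccc(NC(=O)CN3CCCC3)cc2)nc2cc(C(F)(F)F)ccc21` is compound 3 with (((pyrrolidin-1-yl)methyl)carbonyl)amino in place of nitro on an aromatic carbon. Going by the values given here, no measured step covers such a change, and compound 3 sits at the limit, so little can be said. In this assay a step of no size beyond the scatter is expected, since compound 2 gives 90000 nM and is well tolerated. The estimate for compound 4 is 100000 nM, between 30000 nM and 300000 nM. This is expected to be a step of a number no higher from compound 3 to compound 4 (the limit leaves the size open).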

Compound 4, half-maximal cytotoxic concentration: 65000 nM
Compound 4: middle estimate off by 1.5-fold (0.19 log units), on the high side, and the stated range covers the measured number.
By their numbers in this assay, from the lowest: compound 1; then compounds 4 and 2 (each within the scatter of the next). At a limit, above all of these: compound 3.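

In this assay, (((pyrrolidin-1-yl)methyl)carbonyl)amino in place of nitro on an aromatic carbon brings an at least 1.5-fold lower number from compound 3 to compound 4 (0.18 log units; that floor lies within the scatter). Compound 4 thus gives a readable number with this larger group at a position para to a large group, so the change does not bring a step shown to lie beyond the scatter. Compound 3 stands at a limit of the assay and not at a number, so the true size of the step stays open: the limit of > 100000 nM in this assay, at which 1 of the 4 values shown sits.

Which part of the new group matters also stays open. A simple amine on the same carbon, or a longer chain leading to the ring, could separate the effect of the amide from that of the ring.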